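A few compounds are considered here, and "the series" means these few. Any claim that something is new, unique, unknown or untested is made for them only; others in the source may bear on it.

Measured so far:

Compound 1, `Cc1ccccc1-c1nnc(N(C)N)s1`. In a functional assay on the whole organism with Mus musculus as the target, with a stated time of 1 h (a higher number here means that more compound is needed for the effect, a lower number that less compound is needed), compound 1 gives 41 mg/kg.
Compound 2, `CNNc1nnc(-c2ccccc2C)s1`. In this assay compound 2 gives only a limit, > 100 mg/kg, and so sits at the limit of > 100 mg/kg in this assay, at which 1 of the 2 values shown sits.

Compound 2 therefore has no number of its own in this assay: the dose needed for the effect was not reached within the range tested, and only a boundary is known. Within the data shown here, the single measured step, an at least 2.4-fold higher number from compound 1 to compound 2 (0.38 log units; beyond the scatter), moves the methyl from one hydrazine nitrogen to the other; it does not replace that methyl with anything larger, so it says nothing direct about what follows.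

Compound 3, `Cc1ccccc1-c1nnc(NNc2ccccc2)s1`, differs from compound 2 by phenyl in place of methyl on an amine nitrogen. Among the measured compounds shown here, no measured step covers a methyl-to-phenyl exchange at this nitrogen, so neither the direction nor the size of the change can be read from the two values at hand. The plain expectation is that compound 3 stays close to where compound 2 already is, with the step that the limit leaves unreadable from compound 2 to compound 3 an estimate rather than a reading. Compound 3 is estimated at 150 mg/kg in this assay, within a range from 40 mg/kg to 400 mg/kg, with a fair chance that only a limit is reported again.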

Compound 3, dose for half-maximal effect: > 100 mg/kg
Compound 3 gave a limit, no number; the forecaster's own chance of this, stated with the estimate: 65%; the middle value is on the limit's open side.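

Compound 3, like compound 2, gives only a limit in this assay, so no step can be read between compound 2 and compound 3, neither its size nor its direction: the limit of > 100 mg/kg in this assay, at which 2 of the 3 values shown sit. The compounds shown leave open how much of compound 2 or compound 3 the effect needs, and whether phenyl or methyl on that amine nitrogen needs less.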